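Swapping methoxycarbonyl for (diethylamino)methyl on the side chain

The compounds below may be only part of what the source reports. "The series", "measured", "known", "first", "only" and "open" are said of these compounds alone.

In a functional assay on L1210 cells (Mus musculus) for inhibition (on this read-out higher numbers stand for weaker inhibition and lower numbers for stronger inhibition), compound 1 (`COC(=O)CNc1ncnc2c1C(=O)C(OC)=CC2=O`) gives 4260 nM and compound 2 (`COC(=O)C(Nc1ncnc2c1C(=O)C(OC)=CC2=O)C(C)C`) gives 2590 nM. Among the compounds with values here, compound 1 therefore stands level with the only other measured compound, as the two lie within the scatter of each other.

Compound 3 (`CCN(CC)CCNc1ncnc2c1C(=O)C(OC)=CC2=O`) keeps the core of compound 1 and changes only the side chain: (diethylamino)methyl in place of methoxycarbonyl on a saturated chain carbon bound to a nitrogen on an aromatic ring. Put simply, (diethylamino)methyl takes the place of methoxycarbonyl on a saturated chain carbon bound to a nitrogen on an aromatic ring.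

Within the data shown here, only one measured step bears on this, and only loosely: a 1.6-fold lower number from compound 1 to compound 2 (0.22 log units; within the scatter). That step puts isopropyl in place of hydrogen but leaves methoxycarbonyl in place, so no measurement shows what losing that group does. Judging by compound 2, which at 2590 nM stays within the scatter of compound 1, no clear shift is expected in this assay, and the direction remains open. The expected change is a 1.7-fold lower number from compound 1 to compound 3 (0.23 log units; within the scatter). Compound 3 is estimated at 2500 nM, with an expected range from 600 nM to 9000 nM.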

Compound 3, half-maximal inhibitory concentration: 898 nM
Compound 3: middle estimate off by 2.8-fold (0.44 log units), on the high side; the range from low to high includes it.
By their numbers in this assay, from the lowest: compound 3; then compounds 2 and 1 (each within the scatter of the next).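

In this assay, the side chain on this carbon does affect the read-out: (diethylamino)methyl in place of methoxycarbonyl gives a 4.7-fold lower number from compound 1 to compound 3 (0.68 log units; beyond the scatter). The earlier step added isopropyl and kept methoxycarbonyl, and it stayed within the scatter, so this is the first change shown that clearly moves the number, here towards stronger inhibition. The position therefore accepts the loss of methoxycarbonyl, with its two oxygens and its double bond, and the entry of a larger group that holds a nitrogen, but nothing shown explains why inhibition gets stronger.

Because one group replaces the other whole, the compounds shown leave open whether the change in the number goes with the loss of methoxycarbonyl, with the arrival of the amine nitrogen, or with the extra carbons. A plain butyl chain, which has carbon only, a smaller dimethylamine or a ring amine such as piperidine on the same chain would help to separate these, and a longer chain between the two nitrogens would test how far the amine can sit from the core.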